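Methyl on the phenoxy ring of a triazole series

A few compounds are considered here, and "the series" means these few. Any claim that something is new, unique, unknown or untested is made for them only; others in the source may bear on it.

Compound 1 `Brc1ccc(Cn2cc(COc3ccccc3)nn2)cc1` is measured in a physicochemical assay, read by spectrophotometry, with a stated time of 30 min (a higher number here means a weaker inhibitor, a lower number a stronger inhibitor), where compound 1 gives 18.3 ug/mL. Compound 2 `Cc1ccc(OCc2cn(Cc3ccc(Br)cc3)nn2)cc1` carries one change from compound 1, (methyl in place of hydrogen on an aromatic carbon), and in this assay compound 2 gives 16.3 ug/mL; the step of a 1.1-fold lower number from compound 1 to compound 2 (0.05 log units; within the scatter) is therefore one that cannot be told apart from repeat measurements. Compound 3 `O=[N+]([O-])c1ccc(Cn2cc(COc3ccc(Cl)cc3)nn2)cc1` is built on another core; the difference between the two cores is not broken down here. In this assay compound 3 gives 24.2 ug/mL.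

Compound 4 `Cc1cc(OCc2cn(Cc3ccc([N+](=O)[O-])cc3)nn2)ccc1Cl` is not yet measured. It differs from compound 3 by methyl in place of hydrogen on an aromatic carbon. This is the same kind of change as that from compound 1 to compound 2, though the surroundings differ: in compound 2 the methyl sits para to a large group, whereas in compound 4 it sits ortho to a chloro group and meta to a large group. Since the earlier step of a 1.1-fold lower number from compound 1 to compound 2 (0.05 log units; within the scatter) lay within the scatter, the step of a 1.1-fold lower number from compound 3 to compound 4 (0.04 log units; within the scatter) is expected to be small as well. On that basis compound 4 is estimated to give 22 ug/mL in this assay, with a plausible range from 12 ug/mL to 40 ug/mL.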

Compound 4, half-maximal inhibitory concentration: 13.4 ug/mL
Compound 4: middle estimate off by 1.6-fold (0.22 log units), on the high side; measured number inside the range.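

In this assay the new step (a 1.8-fold lower number from compound 3 to compound 4 (0.26 log units; within the scatter)) cannot be told apart from repeat measurements, and the same holds for the earlier step on the other core (a 1.1-fold lower number from compound 1 to compound 2 (0.05 log units; within the scatter)). So the only thing that carries from one core to the other is that methyl in place of hydrogen gives no readable change on either; this does not show that the methyl truly shifts the number, or that the two cores respond alike, and the surroundings of the methyl also differ, as in compound 4 it sits ortho to a chloro group. Nothing available here bears on the reason for either result.

The compounds shown leave open whether a different group in the same place, such as an ethyl chain, a methoxy group or an amine, would move the number beyond the scatter. They also leave open how methyl ortho to a chloro group would behave on the core of compound 1, as each surrounding is seen only once.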